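The compounds below may be only part of what the source reports. "The series", "measured", "known", "first", "only" and "open" are said of these compounds alone.

Two compounds share one core and differ only in the aromatic ring attached to the carbonyl of an amide. Compound 1 `Cc1ccccc1C(=O)Nc1cccc(-c2oc3cc(-c4ccc(F)cc4)ccc3c(=O)c2O)c1` carries a 2-methylphenyl there and gives 24800 nM in a functional assay on GTL 16 cells for antiproliferative activity against GTL 16 cell line (Homo sapiens), read by CCK-8 assay, with a stated time of 72 h; on this read-out higher numbers stand for weaker inhibition and lower numbers for stronger inhibition. Compound 2 `COc1cccc(C(=O)Nc2cccc(-c3oc4cc(-c5ccc(F)cc5)ccc4c(=O)c3O)c2)c1` carries a 3-methoxyphenyl and gives 12500 nM in this assay. The step of a 2.0-fold lower number from compound 1 to compound 2 (0.30 log units; within the scatter) lies within the scatter, so compound 2 stands alongside compound 1 and the two cannot be told apart on these numbers.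

Compound 3 `Cc1cc(C)cc(C(=O)Nc2cccc(-c3oc4cc(-c5ccc(F)cc5)ccc4c(=O)c3O)c2)c1` is the next variation: 3,5-dimethylphenyl in place of 3-methoxyphenyl on a carbonyl carbon. For the measured compounds named here, the only step measured so far is the one from compound 1 to compound 2, where a ring swap at the same carbonyl carbon gave a 2.0-fold lower number from compound 1 to compound 2 (0.30 log units; within the scatter), a change no larger than the usual scatter. A further ring swap at that position is therefore expected to move the number little, with no clear direction.

Compound 3 is thus estimated at about 15000 nM, in a range from 6000 nM to 40000 nM. The step expected is a 1.2-fold higher number from compound 2 to compound 3 (0.08 log units; within the scatter).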

Compound 3, half-maximal inhibitory concentration: 13500 nM
Compound 3: the middle estimate sits 1.1-fold (0.05 log units) above what was measured; low and high end bracket the measured number.
By their numbers in this assay, from the lowest: compounds 2, 3 and 1 (each within the scatter of the next).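

Replacing the 3-methoxyphenyl with 3,5-dimethylphenyl on the carbonyl carbon removes the one hydrogen-bond acceptor of that group, yet in this assay the result is (a 1.1-fold higher number from compound 2 to compound 3 (0.03 log units; within the scatter)). Thus, among these compounds, the methoxy oxygen is not required for a reading in this range, since the all-carbon group cannot be told apart from it. The comparison with the 2-methylphenyl of compound 1 (a 1.8-fold lower number from compound 1 to compound 3 (0.26 log units; within the scatter)) also stays within the scatter, so all three rings at this position read alike, and no measurement at hand offers an explanation.

All three groups are phenyl rings bearing only methyl or methoxy. As far as these compounds go, whether a ring carrying an amine or a carboxylic acid, or a longer chain in place of the ring, would shift the number remains open.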